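Fluoro for Bromo: Expected Cytotoxicity of Compound 4

The source may report more compounds than this note shows. Statements on the series, on what has been measured and on what is new or still open speak of the compounds shown alone.

Of the compounds shown here, three that share a core have been tested in an ADME assay on Vero cells (Chlorocebus sabaeus) for cytotoxicity, read by resazurin assay, with a stated time of 72 h; a lower number here means a stronger inhibitor, a higher number a weaker inhibitor. Compound 1 `O=C(CCN1CCN(c2ccc([N+](=O)[O-])cc2)CC1)c1ccc(F)cc1` gives 111000 nM. Compound 2 `O=C(CCN1CCN(c2ccc([N+](=O)[O-])cc2)CC1)c1ccc(Br)cc1` gives 79800 nM. Compound 3 `O=C(CCN1CCN(c2ccc(F)cc2)CC1)c1ccc(F)c(Br)c1` gives 352000 nM, the highest of the three. Compound 4 `O=C(CCN1CCN(c2ccc(F)cc2)CC1)c1ccc(F)c(F)c1` has not yet been measured in this assay.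

The change from compound 2 to compound 1 is fluoro in place of bromo on an aromatic carbon, and it brought a 1.4-fold higher number from compound 2 to compound 1 (0.14 log units; within the scatter). The change from compound 3 to compound 4 is fluoro in place of bromo on an aromatic carbon. The places are not identical: in compound 2 the bromo sits para to a large group, whereas in compound 3 it sits ortho to a fluoro group and meta to a large group, so this is the same kind of change rather than the same change. The difference between the core of compound 2 and the core of compound 3 is not broken down here.

Since the earlier step lay within the scatter, compound 4 is expected to stay close to compound 3, with an expected step of a 1.2-fold higher number from compound 3 to compound 4 (0.08 log units; within the scatter). The estimate for compound 4 in this assay is 420000 nM, expected between 200000 nM and 900000 nM.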

Compound 4, half-maximal inhibitory concentration: 385000 nM
Compound 4: middle estimate off by 1.1-fold (0.04 log units), on the high side; the range from low to high includes it.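

In this assay, fluoro in place of bromo, here 3-bromo-4-fluorophenyl becoming 3,4-difluorophenyl, gave a 1.1-fold higher number from compound 3 to compound 4 (0.04 log units; within the scatter), so this swap produced no readable difference on this core. Set beside the earlier case, the same kind of change behaves alike on both cores, and its size can be carried from one to the other among these compounds: the same change on two cores in this assay, a 1.4-fold higher number (0.14 log units; within the scatter) from compound 2 to compound 1 and a 1.1-fold higher number (0.04 log units; within the scatter) from compound 3 to compound 4, 1.3-fold (0.10 log units) apart, within the scatter of two such steps

Among the compounds shown here, this shows agreement across only two cores, with the bromo at a different place on each, and both steps are small, so it does not show that the swap would stay this quiet on other cores or at other places, nor does it explain why it was quiet here.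

The compounds shown leave open what a chloro, a methyl or an amine would do at the place held by bromo and fluoro here. They also leave open whether a longer chain between the carbonyl and the rest of the core would alter this picture.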